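A methoxy in place of a carboxy on the aryl urea

The compounds below may be only part of what the source reports. "The series", "measured", "known", "first", "only" and "open" are said of these compounds alone.

Compound 1, `O=C(Nc1cccc(C(=O)O)c1)N[C@H]1CC[C@H](Oc2ccc(F)cc2)CC1`, is the starting point. In a functional assay on CRL2813 cells (Homo sapiens) for cytotoxicity, read by sulforhodamine B assay, with a stated time of 5 days (a lower number here means a stronger inhibitor, a higher number a weaker inhibitor), compound 1 gives only > 20000 nM, which is a limit of the assay and not a number. Compound 2, `O=C(Nc1ccccc1F)N[C@H]1CC[C@H](Oc2ccc(F)cc2)CC1`, gives 17500 nM, and compound 3, `O=C(Nc1ccc(I)cc1)N[C@H]1CC[C@H](Oc2ccc(F)cc2)CC1`, gives 10200 nM. Compound 4, `COc1cccc(NC(=O)N[C@H]2CC[C@H](Oc3ccc(F)cc3)CC2)c1`, differs from compound 1 by methoxy in place of carboxy on an aromatic carbon. Among the measured compounds shown here, two measured steps bear on this change, each replacing the 3-carboxyphenyl with another phenyl: an at least 1.1-fold lower number from compound 1 to compound 2 (0.05 log units; that floor lies within the scatter) and an at least 1.9-fold lower number from compound 1 to compound 3 (0.29 log units; that floor lies within the scatter). Both floors lie within the scatter, so the measured data support at most a modest shift. A modest move toward a lower number is expected, an at least 1.6-fold lower number from compound 1 to compound 4 (0.22 log units; that floor lies within the scatter). Compound 4 is therefore estimated at 12000 nM, with a range from 5000 nM to 30000 nM.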

Compound 4, half-maximal inhibitory concentration: 14000 nM
Compound 4: the middle estimate sits 1.2-fold (0.07 log units) below what was measured; low and high end bracket the measured number.
By their numbers in this assay, from the lowest: compounds 3, 4 and 2 (each within the scatter of the next). At a limit, above all of these: compound 1.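

In this assay, methoxy in place of carboxy gives an at least 1.4-fold lower number from compound 1 to compound 4 (0.15 log units; that floor lies within the scatter); this can be read only as a floor because compound 1 stands at a limit: the limit of > 20000 nM in this assay, at which 1 of the 4 values shown sits. The 3-methoxyphenyl group does not separate from the other two aryl groups, with a 1.4-fold higher number from compound 3 to compound 4 (0.14 log units; within the scatter) and a 1.3-fold lower number from compound 2 to compound 4 (0.10 log units; within the scatter). Among these three aryl ureas, this change of group therefore produces no shift beyond the scatter.

Going by these compounds, whether an amine or a longer chain such as ethoxy on this aromatic carbon would move the number beyond the scatter remains open. On these data alone, the true size of the step away from carboxy also remains open.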